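The compounds below may be only part of what the source reports. "The series", "measured", "known", "first", "only" and "open" are said of these compounds alone.

Two compounds of the series have numbers in a functional assay on MDA-MB-468 cells (Homo sapiens) for cytotoxicity, read by sulforhodamine B assay, with a stated time of 48 h, in the presence of a further agent that is not named here; on this read-out lower numbers stand for stronger inhibition of growth and higher numbers for weaker inhibition of growth. Compound 1 `CCCCNc1ccnc2cc(Cl)ccc12` gives 4300 nM in this assay. For the measured compounds named here, compound 2 `CN(C)CCNc1ccnc2cc(Cl)ccc12` gives 3240 nM in this assay; the step of a 1.3-fold lower number from compound 1 to compound 2 (0.12 log units; within the scatter) is within the scatter, so compound 2 and compound 1 cannot be separated on this read-out, and compound 2 stands level with the only other measured compound.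

Compound 3 `COc1ccc2c(NCCN(C)C)ccnc2c1` is not yet measured. It differs from compound 2 by methoxy in place of chloro on an aromatic carbon. Going by the values given here, the single measured step concerns the saturated chain on the amino nitrogen, not the aromatic ring, so no measured step bears on this change; nothing shows what a substituent swap on the carbon ring does to the read-out.

Among the compounds with values here, with no relevant step to draw on, the expected step of a 1.1-fold higher number from compound 2 to compound 3 (0.03 log units; within the scatter) from compound 2 to compound 3 is none beyond the scatter, with a wide allowance either way. Compound 3 is therefore estimated at 3500 nM in this assay, expected within 1200 nM to 10000 nM.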

Compound 3, concentration for 50% growth inhibition: 5660 nM
The estimate for compound 3 lay 1.6-fold (0.21 log units) below the measured number; the measured number falls inside the stated range.
By their numbers in this assay, from the lowest: compounds 2, 1 and 3 (each within the scatter of the next).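

For the compounds shown here, this is the first measured step on the aromatic ring of the series: on an aromatic carbon of the six-membered aromatic ring of carbon only, methoxy in place of chloro gives a 1.7-fold higher number from compound 2 to compound 3 (0.24 log units; within the scatter) in this assay. Exchanging chloro, with 1 heavy atom and 0 hydrogen-bond acceptors, for methoxy, with 2 heavy atoms and 1 hydrogen-bond acceptor, therefore leaves compound 3 inseparable from compound 2 on this read-out. No measurement at hand accounts for this result.

Open, as far as these compounds go, is whether an amine or trifluoromethyl at this same place would give a step beyond the scatter. Also open, from the compounds shown here alone, is whether methoxy in place of chloro reads the same with the chain of compound 1, or with a longer chain ending in dimethylamino.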